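This account rests on a few compounds, and the source may have more. Where it says the series, first, only, none or still open, it means among the compounds named here.

Measured so far in a functional assay on a cell-free system (plasma, Oryctolagus cuniculus) for inhibition, with stated times of 5 min, 1 min and 6 min; on this read-out higher numbers stand for weaker inhibition and lower numbers for stronger inhibition:
compound 1, `CCOC(=O)c1c(C)nc(-c2ccc(OCC(C)C)c(C#N)c2)n1O`: 16800 nM
compound 2, `CCOC(=O)c1c(C)nc(-c2ccccc2)n1OC`: > 30000 nM
compound 3, `CCOC(=O)c1c(C)nc(-c2cccc(C#N)c2)n1C(C)C`: 9260 nM

Compound 3 holds the lower of the two numbers given, but the number of compound 1 sits within the scatter of it, so no order between the two is claimed. For compound 2 the result is only a limit and not a number, (the limit of > 30000 nM in this assay, at which 1 of the 3 values shown sits). Compound 4, `CCOC(=O)c1c(C)nc(-c2cccc(C#N)c2)n1OCc1cccc(F)c1`, has not yet been measured. Relative to compound 3 the change is (3-fluorobenzyl)oxy in place of isopropyl on an aromatic nitrogen. Among the compounds with values here, no measured pair isolates this change, and the two numbers plus one limit give no basis for a direction. The step from compound 3 to compound 4 in this assay is expected to be a 1.3-fold lower number from compound 3 to compound 4 (0.12 log units; within the scatter), not beyond the usual scatter either way. Compound 4 is therefore estimated at 7000 nM, with a range from 1800 nM to 27000 nM.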

Compound 4, half-maximal inhibitory concentration: 22400 nM
For compound 4 the middle estimate is 3.2-fold (0.51 log units) below the measured one, within the range that was stated.
By their numbers in this assay, from the lowest: compounds 3, 1 and 4 (each within the scatter of the next, the first and the last beyond it). At a limit, above all of these: compound 2.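

Within the data shown here, this is the first pair that isolates a change on the aromatic nitrogen of the shared core: (3-fluorobenzyl)oxy in place of isopropyl gives a 2.4-fold higher number from compound 3 to compound 4 (0.38 log units; beyond the scatter) in this assay. The much larger group, with its aromatic ring, still leaves compound 4 with a number rather than a limit, so this position accepts it at a modest cost. Nothing at hand accounts for the size or direction of this step.

This single pair does not separate the oxygen link, the benzyl ring and the fluorine. From the compounds shown here alone, how a plain benzyl, a longer alkyl chain or an amine would read on this nitrogen remains open.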